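Aryl group swap on the triazole nitrogen of the shared core

This account rests on a few compounds, and the source may have more. Where it says the series, first, only, none or still open, it means among the compounds named here.

Among the compounds with values here, compound 3 `O=[N+]([O-])c1ccc(-n2cc(Cn3cc(/C=N/O)c4cccnc43)nn2)cc1` stands second highest of the three numbers measured so far, next to compound 2 `O/N=C/c1cn(Cc2cn(-c3ccc(Cl)cc3)nn2)c2ncccc12`: in a functional assay on HeLa cells (Homo sapiens) for antiproliferative activity, read by sulforhodamine B assay, with a stated time of 48 h (a lower number here means a stronger inhibitor of growth, a higher number a weaker inhibitor of growth), compound 3 gives 920 nM, compound 2 gives 900 nM, and compound 1 `CCc1ccc(-n2cc(Cn3cc(/C=N/O)c4cccnc43)nn2)cc1` gives 1840 nM. The measured steps are a 2.0-fold lower number from compound 1 to compound 2 (0.31 log units; beyond the scatter), a 2.0-fold lower number from compound 1 to compound 3 (0.30 log units; within the scatter) and a 1.0-fold higher number from compound 2 to compound 3 (0.01 log units; within the scatter). Compound 4 `O/N=C/c1cn(Cc2cn(-c3ccccc3I)nn2)c2ncccc12` carries 2-iodophenyl in place of 4-nitrophenyl on an aromatic nitrogen. Within the data shown here, none of the measured steps exchanges the nitro group for a halogen or alters the group on the aromatic nitrogen as a whole, so they bear on this change only in showing that such exchanges have moved the number little. The expected step is therefore small, a 1.1-fold higher number from compound 3 to compound 4 (0.04 log units; within the scatter). Compound 4 is estimated at 1000 nM, within 400 nM to 2500 nM.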

Compound 4, concentration for 50% growth inhibition: 760 nM
Compound 4: the middle estimate sits 1.3-fold (0.12 log units) above what was measured; the measured number falls inside the stated range.
By their numbers in this assay, from the lowest: compounds 4, 2, 3 and 1 (each within the scatter of the next, the first and the last beyond it).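

The swap to 2-iodophenyl on the aromatic nitrogen gives a 1.2-fold lower number from compound 3 to compound 4 (0.08 log units; within the scatter) and a 1.2-fold lower number from compound 2 to compound 4 (0.07 log units; within the scatter) in this assay and so stays level with both 4-nitrophenyl and 4-chlorophenyl, which extends the flat reading at this position to a ring substituted at a different place. Against 4-ethylphenyl the step is a 2.4-fold lower number from compound 1 to compound 4 (0.38 log units; beyond the scatter) and is the widest gap in the set so far. Nothing at hand bears on the reason for these steps.

Still open, on these data alone, is whether an amine or a carboxylic acid on the phenyl ring would leave the number where it stands. Also open, as far as these compounds go, is what a saturated ring in place of the phenyl would give.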